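A Bulkier Amide Substituent on a Weakly Active Series

A few compounds are considered here, and "the series" means these few. Any claim that something is new, unique, unknown or untested is made for them only; others in the source may bear on it.

Compound 2 `CC(C)NC(=O)c1ccc(NCc2cncn2Cc2ccc(C#N)cc2)cc1-c1ccccc1` was examined in a functional assay on NIH3T3 cells (Mus musculus); on this read-out lower numbers stand for an effect already at smaller amounts and higher numbers for an effect only at larger amounts of compound. In this assay compound 2 reaches only the limit > 10 uM, a bound of the measurement rather than a number. Compound 1 `COC(=O)[C@H](CCSC)NC(=O)c1ccc(CNCc2cncn2Cc2ccc(C#N)cc2)cc1-c1ccccc1C` likewise stops at the limit > 10 uM. Compound 3 `CCOC(=O)[C@H](CCSC)NC(=O)c1ccc(CNCc2c[nH]cn2)cc1-c1ccccc1C` gives 10 uM. The picture is one of weak effects throughout: the limit of > 10 uM in this assay, at which 2 of the 3 values shown sit, and the third value stands at the same concentration. Compound 4 `N#Cc1ccc(Cn2cncc2CNc2ccc(C(=O)NCC3CCCCC3)c(-c3ccccc3)c2)cc1` differs from compound 2 in one place (cyclohexylmethyl in place of isopropyl on an amide-type nitrogen). Among the measured compounds shown here, no measured pair shows this change, so its effect is unknown from the data; the expected a number no higher from compound 2 to compound 4 (the limit leaves the size open) is no larger than the usual scatter. Compound 4 is therefore estimated at 10 uM, with a likely range from 3 uM to 30 uM.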

Compound 4, concentration for half-maximal effect: > 10 uM
Compound 4 ended at the assay's limit; the forecaster's own chance of this, stated with the estimate: 60%; the middle value lies on the limit itself.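

In this assay, among the compounds shown here, compound 2 and compound 4 both stop at a limit of the measurement, so no step between them can be read. The compounds shown leave open whether cyclohexylmethyl in place of isopropyl on the amide-type nitrogen changes the effect at all.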